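Extending the sulfonamide chain: compound 3 to compound 4

A few compounds are considered here, and "the series" means these few. Any claim that something is new, unique, unknown or untested is made for them only; others in the source may bear on it.

Three compounds share the core of compound 1 `Cc1cccnc1-c1ccc(C(=O)Nc2ccc(C(C)(C)C)cc2)cc1`, which in a functional assay for antagonist activity at transient receptor potential cation channel subfamily V member 1 (Homo sapiens), read by FLIPR (a lower number here means a stronger inhibitor, a higher number a weaker inhibitor), gives 11 nM. Compound 2 `CCCNc1cccnc1-c1ccc(C(=O)Nc2ccc(C(C)(C)C)cc2)cc1` carries propylamino in place of methyl on an aromatic carbon, and in this assay compound 2 gives 158 nM, a step of a 14-fold higher number from compound 1 to compound 2 (1.16 log units; beyond the scatter). Compound 3 `CC(C)(C)c1ccc(NC(=O)c2ccc(-c3ncccc3NS(C)(=O)=O)cc2)cc1` carries methanesulfonamido in place of that methyl; in this assay compound 3 gives 152 nM, a step of a 14-fold higher number from compound 1 to compound 3 (1.14 log units; beyond the scatter). Compound 3 thus stands second highest of the three numbers, with compound 2 nearest and compound 1 furthest; the exchange of methylsulfonyl for propyl on the nitrogen on the aromatic ring reads a 1.0-fold lower number from compound 2 to compound 3 (0.02 log units; within the scatter).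

Compound 4 `CCS(=O)(=O)Nc1cccnc1-c1ccc(C(=O)Nc2ccc(C(C)(C)C)cc2)cc1` is the next step: methyl in place of hydrogen on a saturated chain carbon bound to a sulfonyl sulfur. Going by the values given here, no measured step touches this chain carbon. The step that bears most on it is a 1.0-fold lower number from compound 2 to compound 3 (0.02 log units; within the scatter), in which a quite different group on that nitrogen stayed within the scatter; the large steps of a 14-fold higher number from compound 1 to compound 2 (1.16 log units; beyond the scatter) and a 14-fold higher number from compound 1 to compound 3 (1.14 log units; beyond the scatter) concern the exchange at the aromatic carbon, not the chain. A step of a 1.0-fold lower number from compound 3 to compound 4 (0.01 log units; within the scatter) is therefore expected, nothing beyond the scatter. Compound 4 is estimated at 150 nM, in the range 60 nM to 400 nM.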

Compound 4, half-maximal inhibitory concentration: 49 nM
Beside the measured number, compound 4's estimate is 3.1-fold (0.49 log units) above it; the measured number lies below the stated range.
By their numbers in this assay, from the lowest: compound 1; then compound 4; then compounds 3 and 2 (each within the scatter of the next).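

Working notes: the sulfonyl chain is not a silent position. In this assay, methyl in place of hydrogen on a saturated chain carbon bound to a sulfonyl sulfur gives a 3.1-fold lower number from compound 3 to compound 4 (0.49 log units; beyond the scatter) and so separates the two sulfonamides, while ethylsulfonyl in place of propyl on the nitrogen gives a 3.2-fold lower number from compound 2 to compound 4 (0.51 log units; beyond the scatter) where methylsulfonyl gave only a 1.0-fold lower number from compound 2 to compound 3 (0.02 log units; within the scatter) and no readable change. The single added methyl recovers only part of the loss seen on leaving the methyl of compound 1, as (ethylsulfonyl)amino on the aromatic carbon still leaves a 4.5-fold higher number from compound 1 to compound 4 (0.65 log units; beyond the scatter) and compound 1 holds the lowest number of the four. No supporting data on hand speak to what lies behind this shift.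

On these data alone, one added carbon is a single step and not yet a trend, so it remains open whether a longer chain such as propylsulfonyl or butylsulfonyl, or a branched isopropylsulfonyl, would lower the number further or reverse it. Also open, as far as these compounds go, is how a cyclopropylsulfonyl or phenylsulfonyl group would read on the same nitrogen, and whether an acetamido group would keep the gain without the sulfonyl.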